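Replacing tert-butoxycarbonyl with benzyl on an amine nitrogen

This account rests on a few compounds, and the source may have more. Where it says the series, first, only, none or still open, it means among the compounds named here.

Compound 1 `CSCC[C@H](NC(=O)c1ccc(CN[C@H](C)CC2CCCCC2)cc1-c1ccccc1C)C(=O)O` reads > 1000 nM in a functional assay for inhibition, with Rattus norvegicus as the target (on this read-out higher numbers stand for an effect only at larger amounts of compound and lower numbers for an effect already at smaller amounts), and this is a limit of the assay, not a number. Compound 2 `CSCC[C@H](NC(=O)c1ccc(CN[C@H](CCCC(C)C)CC2CCCCC2)cc1-c1ccccc1C)C(=O)O` gives 52 nM in this assay and compound 3 `CSCC[C@H](NC(=O)c1ccc(CN(CCC2CCCCC2)C(=O)OC(C)(C)C)cc1-c1ccccc1C)C(=O)O` gives 160 nM as the higher of these two numbers, a gap beyond the scatter.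

Compound 4 `CSCC[C@H](NC(=O)c1ccc(CN(CCC2CCCCC2)Cc2ccccc2)cc1-c1ccccc1C)C(=O)O` differs from compound 3 by benzyl in place of tert-butoxycarbonyl on an amine nitrogen. Among the compounds with values here, the one measured step is an at least 19-fold lower number from compound 1 to compound 2 (1.28 log units; beyond the scatter) and it is large, yet it falls on a saturated chain carbon and not on the amine nitrogen, so it gives neither size nor direction for this change. Within the data shown here, no measured step touches this substituent on the nitrogen. The expected step is a 1.2-fold lower number from compound 3 to compound 4 (0.09 log units; within the scatter) and so no shift beyond the scatter is expected. In this assay compound 4 is estimated at 130 nM with a range of 30 nM to 600 nM as the expected span.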

Compound 4, half-maximal effective concentration: > 1000 nM
Compound 4 gave a limit, no number; the forecaster's own chance of this, stated with the estimate: 15%; middle value at least 7.6-fold (0.88 log units) away from the limit.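

Within the data shown here, on the amine nitrogen, the substituent matters in this assay: benzyl in place of tert-butoxycarbonyl gives an at least 6.2-fold higher number from compound 3 to compound 4 (0.79 log units; beyond the scatter), the first measured change at this nitrogen. The two groups have the same count of heavy atoms, so that count alone does not set the read-out here; they differ in that tert-butoxycarbonyl has oxygen and a carbonyl, and benzyl has a six-membered aromatic ring. Compound 4 gives a limit of the assay, not a number, so only a minimum size is known for this step: the limit of > 1000 nM in this assay, at which 2 of the 4 values shown sit.

The compounds shown leave open whether the loss of the carbonyl and oxygen or the arrival of the aromatic ring goes with the step, as the two changes come together here. They also leave open how an acetyl group, a methoxycarbonyl group or a plain hydrogen on this nitrogen would read.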